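The source may report more compounds than this note shows. Statements on the series, on what has been measured and on what is new or still open speak of the compounds shown alone.

The compounds in this set share one core and differ in the groups hung from it, and each was tested in an ADME assay on LLC-MK2 cells (Macaca mulatta) for cytotoxicity, read by spectrophotometry and crystal violet staining, with a stated time of 4 days; on this read-out higher numbers stand for lower toxicity in this test and lower numbers for higher toxicity in this test. Compound 1 `CC(C)n1ncc2c(C(=O)Nc3ccccc3F)cc(-c3cccnc3)nc21` gives 50000 nM in this assay. Compound 2 `CC(C)n1ncc2c(C(=O)Nc3ccccn3)cc(-c3ccsc3)nc21` gives 25000 nM in this assay. Compound 3 `CC(C)n1ncc2c(C(=O)Nc3cccc(F)c3)cc(-c3cccs3)nc21` is reported only as > 200000 nM in this assay, which is a limit rather than a number. Compound 3 thus stands at the limit of > 200000 nM in this assay, at which 1 of the 3 values shown sits, the only one of the three to do so.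

The next compound, compound 4 `CC(C)n1ncc2c(C(=O)Nc3ccncc3)cc(-c3cccs3)nc21`, comes from compound 3 through one change: pyridin-4-yl in place of 3-fluorophenyl on an amide-type nitrogen. No step between two measured compounds is shown, so the effect of such a change cannot be read from the data. Still, compound 2, which also carries a pyridine on the amide nitrogen, gives 25000 nM in this assay, so a move toward higher toxicity is expected, of a size about an at least 2.0-fold lower number from compound 3 to compound 4 (0.30 log units; that floor lies within the scatter). Compound 4 is expected to give about 100000 nM in this assay, with a likely range from 30000 nM to 200000 nM.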

Compound 4, half-maximal cytotoxic concentration: 6300 nM
Compound 4: the middle estimate sits 16-fold (1.20 log units) above what was measured, outside the stated range (below it).
By their numbers in this assay, from the lowest: compound 4; then compounds 2 and 1 (each within the scatter of the next). At a limit, above all of these: compound 3.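

In this assay, the group on the amide-type nitrogen proves able to shift the read-out strongly: pyridin-4-yl in place of 3-fluorophenyl gives an at least 31-fold lower number from compound 3 to compound 4 (1.50 log units; beyond the scatter). Among these compounds, this is the first step here between compounds that differ in one place, and it points toward higher toxicity in this test. Compound 3 is held only as a limit, so this step gives a floor and the true gap may be larger: the limit of > 200000 nM in this assay, at which 1 of the 4 values shown sits.

Because this single change removes a fluorine and adds a ring nitrogen together, the pair cannot show which of the two matters, and a plain phenyl or a saturated piperidine ring on that nitrogen would be needed to separate them. Compounds 1 and 2 differ from the others in more than one place, so no further steps can be read from them.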